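Methyl Added to the Phenyl of Compound 1

A few compounds are considered here, and "the series" means these few. Any claim that something is new, unique, unknown or untested is made for them only; others in the source may bear on it.

Measured so far:
Compound 1, `Cc1ccc(Cc2nc(N)n(CC(=O)Nc3ccccc3)c2-c2ccccc2Br)cc1`, gives 9200 nM in a functional assay on MIA PaCa-2 cells (Homo sapiens) for antiproliferative activity, read by MTT assay, with a stated time of 48 h; a higher number here means a weaker inhibitor, a lower number a stronger inhibitor.
Compound 2, `CC(C)(C)c1ccc(Cc2nc(N)n(CC(=O)Nc3ccccc3)c2-c2ccccc2Br)cc1`, gives 4900 nM in this assay.

Compound 1 stands at the higher of the two numbers in this assay, with compound 2 nearest by a 1.9-fold lower number from compound 1 to compound 2 (0.27 log units; within the scatter), so the two are not separated beyond the scatter.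

Compound 3, `Cc1ccc(Cc2nc(N)n(CC(=O)Nc3ccc(C)cc3)c2-c2ccccc2Br)cc1`, has not yet been measured. It differs from compound 1 by methyl in place of hydrogen on an aromatic carbon. Within the data shown here, the only step known so far, a 1.9-fold lower number from compound 1 to compound 2 (0.27 log units; within the scatter), concerns a different place in the molecule: there a tert-butyl took the place of a methyl on the other phenyl ring, and the number barely moved. Among the measured compounds shown here, no measured pair shows what a methyl on the phenylcarbamoyl ring does, so there is nothing to point in either direction. The expectation for compound 3 in this assay is therefore no step beyond the scatter, that is a 1.1-fold lower number from compound 1 to compound 3 (0.03 log units; within the scatter). Compound 3 is estimated at 8500 nM, with a range from 3000 nM to 25000 nM.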

Compound 3, half-maximal inhibitory concentration: 2900 nM
Compound 3: middle estimate off by 2.9-fold (0.47 log units), on the high side; measured number below the stated range.
By their numbers in this assay, from the lowest: compounds 3, 2 and 1 (each within the scatter of the next, the first and the last beyond it).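

Placing a methyl on the phenyl ring of the phenylcarbamoyl group, which turns it into (4-methylphenyl)carbamoyl, gives the first step in this assay that lies beyond the scatter: a 3.2-fold lower number from compound 1 to compound 3 (0.50 log units; beyond the scatter). The step is modest, but it shows that this ring position, para to a large group, can register a change as small as one added carbon, whereas swapping methyl for tert-butyl on the other phenyl ring gave only a 1.9-fold lower number from compound 1 to compound 2 (0.27 log units; within the scatter), which stays within the scatter. Nothing measured for these compounds explains why the added methyl lowers the number.

A single methyl at a single position cannot show whether this step is specific to methyl, or whether an ethyl, a methoxy, a chlorine, an amine or a carboxylic acid at the same place would lower the number further, leave it unchanged or raise it. Among these compounds, it also remains open whether the same methyl would give a similar step on the tert-butyl compound 2, since the only pair showing this change carries a methyl on the other phenyl ring.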